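The source may report more compounds than this note shows. Statements on the series, on what has been measured and on what is new or still open speak of the compounds shown alone.

Compound 1 `CCCCN(C)/N=N/c1ccc(C(=O)O)cc1` has the lowest reading of the three measured compounds: in a physicochemical assay for lipophilicity (on this read-out higher numbers stand for higher lipophilicity and lower numbers for lower lipophilicity), compound 1 gives 0.97, compound 2 `CCCCCN(C)/N=N/c1ccc(C(=O)O)cc1` gives 1.49 and compound 3 `CCCCCCN(C)/N=N/c1ccc(C(=O)O)cc1` gives 1.95. Compound 4 `CCCCN(C)/N=N/c1ccc(C(N)=O)cc1` differs from compound 1 by amino in place of hydroxy on a carbonyl carbon. The measured steps all lengthen the chain: a number 0.52 log units higher from compound 1 to compound 2 (beyond the scatter), a number 0.46 log units higher from compound 2 to compound 3 (beyond the scatter) and a number 0.98 log units higher from compound 1 to compound 3 (beyond the scatter). From the compounds shown here alone, none of them touches the carbonyl carbon, so they say little about this step, and the expected size and direction for compound 4 in this assay remain open. The estimate for compound 4 in this assay is 1.6, between 0.4 and 2.8, which would mean an expected step of a number 0.63 log units higher from compound 1 to compound 4 (beyond the scatter).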

Compound 4, partition coefficient: 2.46
For compound 4 the middle estimate is 0.86 log units below the measured one; low and high end bracket the measured number.
By their numbers in this assay, from the lowest: compound 1; then compound 2; then compound 3; then compound 4.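

In this assay, the change from carboxy to carbamoyl gives a number 1.49 log units higher from compound 1 to compound 4 (beyond the scatter), showing that this carbonyl carbon, untouched by the chain steps, is a sensitive place. This single-atom exchange even outruns the ethyl step, a number 0.98 log units higher from compound 1 to compound 3 (beyond the scatter), although the computed donor count and net charge stay the same. Nothing measured here gives a reason for the step.

From the compounds shown here alone, whether a methyl ester on the same carbonyl carbon would read nearer compound 1 or compound 4 stays open. So does whether the step keeps its size on the longer chains of compound 2 and compound 3.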